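The source may report more compounds than this note shows. Statements on the series, on what has been measured and on what is new or still open speak of the compounds shown alone.

Among the measured compounds shown here, compound 1 `CCCCCNc1nc(NCc2ccco2)c2cc(F)ccc2n1` is the only member of this small set with a number: in a functional assay on DU-145 cells (Homo sapiens) for cytotoxicity, read by MTT assay, with a stated time of 2 days, tested at 10 uM (a lower number here means less inhibition, a higher number more inhibition at the concentration tested (going by the name of the read-out)), compound 1 gives 83.6%. Compound 2 `CCCCCNc1nc(NCc2ccco2)c2ccccc2n1` shares the furan-bearing core but carries no fluorine, and in this assay compound 2 stands at "not determined" (no result reported), so no single number is available for it. Compound 3 `Fc1ccc2nc(NCCN3CCN(c4cccc(Cl)c4Cl)CC3)nc(NCc3ccco3)c2c1` likewise stands at "not determined" (no result reported) in this assay. Compound 4 `CCCCNc1nc(NCc2ccco2)c2ccccc2n1` has not yet been measured. It differs from compound 2 by hydrogen in place of methyl on a saturated chain carbon, four bonds along the chain from a nitrogen on an aromatic ring. For the measured compounds named here, with no step between measured compounds to lean on, the size of the step in this assay cannot be read from the data; the only anchor is compound 1 and its 83.6%. On that basis compound 4 is expected to give about 72% in this assay, within a range of 45% to 92%.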

Compound 4, a percentage reported as inhibition, at one concentration (the size of the read-out at that concentration, not a potency): 89.9%
Compound 4: middle estimate off by 17.9 percentage points, on the low side; the measured number falls inside the stated range.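

Among the compounds shown here, compound 2 has no single number in this assay, so no step to compound 4 can be read. From the compounds shown here alone, what the change from methyl to hydrogen does to inhibition stays open, and no evidence bears on this result.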